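Swapping a Phenyl for a Trimethoxyphenyl on a Shared Core

This account rests on a few compounds, and the source may have more. Where it says the series, first, only, none or still open, it means among the compounds named here.

Of the compounds shown here, two have been measured in a functional assay on HCC 2998 cells (Homo sapiens) for inhibition; a lower number here means a stronger inhibitor of growth, a higher number a weaker inhibitor of growth. Compound 1, `COc1cc(/C=C/C(=O)c2cccc(-n3cc(-c4ccccc4)[nH]c3=O)c2)cc(OC)c1OC`, gives 1260 nM. Compound 2, `COc1ccc(-c2cn(-c3cccc(C(=O)/C=C/c4ccc(O)c(OC)c4)c3)c(=O)[nH]2)cc1`, gives 2320 nM in this assay. Compound 1 has the lower of the two numbers, yet the gap to compound 2 stays within the usual scatter, so no order between them can be claimed.

Compound 3, `COc1cc(/C=C/C(=O)c2cccc(-n3cc(-c4cc(OC)c(OC)c(OC)c4)[nH]c3=O)c2)cc(OC)c1OC`, is compound 1 with one change: 3,4,5-trimethoxyphenyl in place of phenyl on an aromatic carbon. Within the data shown here, no measured pair shows this exact change, so its effect can only be guessed from the two numbers at hand. The step from compound 1 to compound 3 is expected to be modest, most likely toward a somewhat lower number, though a result within the scatter would not surprise. Compound 3 is therefore estimated at 800 nM in this assay, with a range from 250 nM to 2500 nM, which means an expected step of a 1.6-fold lower number from compound 1 to compound 3 (0.20 log units; within the scatter).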

Compound 3, concentration for 50% growth inhibition: 1920 nM
The estimate for compound 3 lay 2.4-fold (0.38 log units) below the measured number; measured number inside the range.
By their numbers in this assay, from the lowest: compounds 1, 3 and 2 (each within the scatter of the next).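

Among these compounds, putting 3,4,5-trimethoxyphenyl in place of phenyl on this aromatic carbon of the five-membered ring gives a 1.5-fold higher number from compound 1 to compound 3 (0.18 log units; within the scatter) in this assay and is the first direct reading of a change at this position. The group grows from 6 to 12 heavy atoms and brings 3 hydrogen-bond acceptors where phenyl has 0, yet this large change does not separate compound 1 from compound 3 in this measurement. No available measurement bears on why the two compounds read alike.

From the compounds shown here alone, it remains open whether this position would respond to a different kind of group, such as an amine or a carboxylic acid in place of the aromatic ring. A single step also cannot show whether the same swap would read the same way on a different core.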